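Swapping Fluoro for Trifluoromethyl on a Phenylurea

The compounds below may be only part of what the source reports. "The series", "measured", "known", "first", "only" and "open" are said of these compounds alone.

Measured so far:
Compound 1, `C[C@@H](NC(=O)Nc1cccc(C(F)(F)F)c1)c1ccccc1`: 72%
Compound 2, `C[C@@H](NC(=O)Nc1cccc(F)c1F)c1ccccc1`: 99%

Both compounds share the same core and were tested in an ADME assay on the whole organism with Oryza sativa as the target, tested at 1 uM; on this read-out lower numbers stand for a stronger effect and higher numbers for a weaker effect at the one concentration tested. In this assay compound 1 gives 72%, and compound 2 gives 99%. Compound 2 therefore stands highest of the two numbers, which on this read-out means the weaker effect, and its gap to compound 1 lies beyond the usual scatter.

Compound 3, `C[C@@H](NC(=O)Nc1cccc(C(F)(F)F)c1F)c1ccccc1`, has not yet been measured in this assay. Its change from compound 2 is trifluoromethyl in place of fluoro on an aromatic carbon. Among the compounds with values here, no measured pair shows this exact step, but compound 1, which also carries a trifluoromethyl group, gives 72%, a lower number than compound 2. Because compound 1 gives 72%, the expected step of a number 21 percentage points lower from compound 2 to compound 3 (beyond the scatter) is downward and beyond the scatter. For compound 3 the estimate in this assay is 78%, with a range from 60% to 96%.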

Compound 3, a percentage reported as activity, at one concentration (the size of the read-out at that concentration, not a potency): 99%
Estimate against measurement, compound 3: 21 percentage points below; the whole stated range lies below it.
By their numbers in this assay, from the lowest: compound 1; then compounds 2 and 3 (each within the scatter of the next).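

In this assay, trifluoromethyl in place of fluoro on an aromatic carbon brings no change at the digits printed from compound 2 to compound 3 (within the scatter), so at this position, ortho to a fluoro group, the two groups cannot be told apart on this read-out. The other step, fluoro in place of hydrogen on an aromatic carbon, brings a number 27 percentage points higher from compound 1 to compound 3 (beyond the scatter), so the lower number seen with trifluoromethyl in compound 1 does not persist once that fluoro is present. Nothing measured here explains either step. Still open, on these data alone, is whether an amine or a carboxylic acid on this aromatic carbon would shift the number away from those of compound 2 and compound 3. Also open, as far as these compounds go, is whether a chlorine atom in place of the added fluoro would give the same rise from compound 1.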